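The source may hold more compounds than are shown below. What is called first, only, known or untested is meant among the compounds shown, and "the series" means these compounds.

Compound 1, `CCCCCCCCCCCCCCCC(O)CC(O)CO`: 3.2 ug/mL
Compound 2, `C=CCCCCCCCCCCCC(O)CC(O)CO`: 4.4 ug/mL

Both compounds were tested in a functional assay on MCF7 cells (Homo sapiens) for cytotoxicity, read by MTT assay; a higher number here means a weaker inhibitor, a lower number a stronger inhibitor. Within the data shown here, only one measured step exists, a 1.4-fold higher number from compound 1 to compound 2 (0.14 log units; within the scatter), and it lies within the scatter; on these numbers compound 2 cannot be told apart from compound 1, and neither can be called the stronger or weaker of the two.

Compound 3, `C#CCCCCCCCCCCCC(O)CC(O)CO`, has not yet been measured. It differs from compound 2 by ethynyl in place of vinyl on a saturated chain carbon, ten or more bonds along the chain from an oxygen on a saturated carbon. Among the measured compounds shown here, the one measured step bears on this change only loosely: it too altered the far end of the chain, away from the oxygens, and a 1.4-fold higher number from compound 1 to compound 2 (0.14 log units; within the scatter) stayed within the scatter. On that basis the step expected in this assay is a 1.0-fold higher number from compound 2 to compound 3 (0.01 log units; within the scatter), that is, nothing beyond the scatter in either direction. Compound 3 is therefore estimated at 4.5 ug/mL, with a likely range from 2.2 ug/mL to 9 ug/mL.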

Compound 3, half-maximal inhibitory concentration: 6.5 ug/mL
Compound 3: middle estimate off by 1.4-fold (0.16 log units), on the low side; the range from low to high includes it.
By their numbers in this assay, from the lowest: compounds 1, 2 and 3 (each within the scatter of the next, the first and the last beyond it).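

In this assay, putting ethynyl in place of vinyl on a saturated chain carbon, ten or more bonds along the chain from an oxygen on a saturated carbon, gives a 1.5-fold higher number from compound 2 to compound 3 (0.17 log units; within the scatter) and so leaves the triple bond and the double bond indistinguishable at this place. Among these compounds, the comparison with butyl adds something new: ethynyl in its place gives a 2.0-fold higher number from compound 1 to compound 3 (0.31 log units; beyond the scatter) and is the first step here to pass the scatter, though only modestly, so the group at this place is not wholly without effect on the number. No independent measurement is available to explain this small step.

The compounds shown leave open whether a carboxylic acid or an amine at this place would give a larger step. They also leave open what a longer chain would do to the number.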